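From methoxy to ethoxy at the assay ceiling

The compounds below may be only part of what the source reports. "The series", "measured", "known", "first", "only" and "open" are said of these compounds alone.

Compound 1 `N#CC1=C(N)Oc2c(N)cc3nc4ccccc4nc3c2C12C(=O)N(Cc1cnnn1-c1ccccc1Br)c1ccccc12` in a functional assay on MCF7 cells (Homo sapiens) for antiproliferative activity, read by MTT assay, with a stated time of 48 h; a higher number here means a weaker inhibitor, a lower number a stronger inhibitor: 30700 nM
Compound 2 `COc1ccc(-n2nncc2CN2C(=O)C3(C(C#N)=C(N)Oc4c(N)cc5nc6ccccc6nc5c43)c3ccccc32)cc1` in this assay: > 50000 nM

The two measured compounds share one core and differ only in the group on an aromatic nitrogen. The value of compound 2 in this assay is a limit of the assay, not a number, and it sits at the limit of > 50000 nM in this assay, at which 1 of the 2 values shown sits. The step of an at least 1.6-fold higher number from compound 1 to compound 2 (0.21 log units; that floor lies within the scatter) is therefore known only as a floor, and that floor lies within the scatter.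

Compound 3 `CCOc1ccc(-n2nncc2CN2C(=O)C3(C(C#N)=C(N)Oc4c(N)cc5nc6ccccc6nc5c43)c3ccccc32)cc1` keeps everything in compound 2 except for (methyl in place of hydrogen on a saturated chain carbon bound to an oxygen on an aromatic ring), that is, methyl in place of hydrogen on a saturated chain carbon bound to an oxygen on an aromatic ring, read one bond further out as methoxy to ethoxy. Among the measured compounds shown here, no measured step touches this position; the only measured step, an at least 1.6-fold higher number from compound 1 to compound 2 (0.21 log units; that floor lies within the scatter), changes a different part of the aromatic ring and gives no more than a floor. Because compound 2 already stands at the limit of > 50000 nM in this assay, at which 1 of the 2 values shown sits, a small change of this kind has little room to show. For compound 3 the expected step is a step that the limit leaves unreadable from compound 2 to compound 3, none beyond the scatter. Compound 3 is estimated at 60000 nM in this assay, within 25000 nM to 150000 nM, and most likely reported again only as a limit.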

Compound 3, half-maximal inhibitory concentration: 26800 nM
For compound 3 the middle estimate is 2.2-fold (0.35 log units) above the measured one; the range from low to high includes it.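

In this assay, compound 3, with its 4-ethoxyphenyl group, gives a real number, 26800 nM, so this position now has a measured value to work from. The value of compound 2 is a limit of the assay and not a number, so the change from methoxy to ethoxy is known only as a floor, an at least 1.8-fold lower number from compound 2 to compound 3 (0.27 log units; that floor lies within the scatter), and no real gain from the added methyl can be claimed. Among the compounds shown here, compound 3 also gives a first direct comparison between 4-ethoxyphenyl and 2-bromophenyl, and the two groups cannot be told apart here, with a 1.1-fold lower number from compound 1 to compound 3 (0.06 log units; within the scatter).

As far as these compounds go, how far the true value of compound 2 lies past its limit remains unknown, which leaves the real size of the methoxy to ethoxy step open. Also open, from the compounds shown here alone, is whether a longer chain such as propoxy, or an amine in place of the ethoxy group, would shift the number beyond the scatter.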